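A Second Methoxy on the Aryl Ring of Compound 1

A few compounds are considered here, and "the series" means these few. Any claim that something is new, unique, unknown or untested is made for them only; others in the source may bear on it.

Within the data shown here, compound 1 `COc1ccc([C@@H]2CCc3c(OC)cc(OC)cc3O2)cc1` is one of two compounds measured so far in a functional assay on U-937 cells (Homo sapiens) for antiproliferative activity, read by WST assay, with a stated time of 24 h (on this read-out lower numbers stand for stronger inhibition and higher numbers for weaker inhibition), where compound 1 gives 29000 nM. Compound 2 `COc1cc(OC)c2c(c1)O[C@H](c1ccc(O)cc1)CC2` in this assay gives 39000 nM, and the step of a 1.3-fold higher number from compound 1 to compound 2 (0.13 log units; within the scatter) lies within the scatter; it concerns hydrogen in place of methyl on an oxygen on an aromatic ring. Compound 3 `COc1ccc([C@@H]2CCc3c(OC)cc(OC)cc3O2)c(OC)c1` has not yet been measured. It differs from compound 1 by methoxy in place of hydrogen on an aromatic carbon. Among the measured compounds shown here, no measured step concerns a methoxy entering in place of hydrogen on an aromatic carbon, so the single step at hand does not bear directly on this change; it shows only that altering a methoxy elsewhere on the same scaffold left the number within the scatter. With nothing pointing in either direction, the step of no change at the digits printed from compound 1 to compound 3 (within the scatter) is expected to stay within the scatter. For the measured compounds named here, compound 3 in this assay is therefore estimated at 29000 nM, with a range from 10000 nM to 85000 nM, the width reflecting that no relevant step has yet been measured.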

Compound 3, half-maximal inhibitory concentration: > 100000 nM
Compound 3: a limit, no number; the forecaster's own chance of this, stated with the estimate: 10%; middle value at least 3.4-fold (0.53 log units) from the limit.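

The value of compound 3 in this assay is a limit of the assay and not a number, and any reading of this position rests on that limit: the limit of > 100000 nM in this assay, at which 1 of the 3 values shown sits.

Even so, the step is readable in one direction, an at least 3.4-fold higher number from compound 1 to compound 3 (0.53 log units; beyond the scatter), and it shows that a methoxy entering on this aromatic carbon, ortho to a large group and meta to a methoxy group, carries the number beyond the scatter. Among these compounds, the only earlier step, a 1.3-fold higher number from compound 1 to compound 2 (0.13 log units; within the scatter), gave no such sign, so this position is the first place on the core of compound 1 where a single change is seen to weaken inhibition in this assay.

The compounds shown leave open whether this step belongs to the methoxy itself or to any group at this place, and a fluorine, a hydroxyl or an amine on the same carbon would bear on that question. They also leave open how large the step truly is, since the limit fixes only one side of it.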